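Swapping the chain amine: pyrrolidine to methylpiperazine

The compounds below may be only part of what the source reports. "The series", "measured", "known", "first", "only" and "open" are said of these compounds alone.

Compound 2 `COc1cc2c(Oc3ccc(NC(=O)c4nn(-c5cccc(F)c5)c(=O)cc4C)cc3F)ccnc2cc1OCCCN1CCCC1` and compound 1 `COc1cc2c(Oc3ccc(NC(=O)c4nn(-c5ccccc5OC(F)(F)F)c(=O)cc4C)cc3F)ccnc2cc1OCCCN1CCN(C)CC1` share one core and differ in two places. In a functional assay on U-87MG ATCC cells (Homo sapiens) for inhibition, read by MTT assay, with a stated time of 72 h (a lower number here means a stronger inhibitor, a higher number a weaker inhibitor), compound 2 gives 1700 nM, and compound 1 gives 1440 nM; the two numbers lie within the scatter of each other, so neither stands apart. Compound 3 `COc1cc2c(Oc3ccc(NC(=O)c4nn(-c5cccc(F)c5)c(=O)cc4C)cc3F)ccnc2cc1OCCCN1CCN(C)CC1` is compound 2 with 4-methylpiperazin-1-yl in place of pyrrolidin-1-yl on a saturated chain carbon, three bonds along the chain from an oxygen on an aromatic ring. Among the compounds with values here, no measured pair isolates this single change. Because compound 1 carries the same amine and gives 1440 nM in this assay, the step of a 1.1-fold lower number from compound 2 to compound 3 (0.05 log units; within the scatter) is expected to be small, nothing beyond the scatter. Compound 3 is therefore estimated at 1500 nM, with a range from 700 nM to 3200 nM.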

Compound 3, half-maximal inhibitory concentration: 1590 nM
For compound 3 the middle estimate is 1.1-fold (0.03 log units) below the measured one; the range from low to high includes it.
By their numbers in this assay, from the lowest: compounds 1, 3 and 2 (each within the scatter of the next).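

In this assay, within the data shown here, the step of a 1.1-fold lower number from compound 2 to compound 3 (0.03 log units; within the scatter) is the first reading of this amine swap alone: on this saturated chain carbon, 4-methylpiperazin-1-yl and pyrrolidin-1-yl cannot be told apart. The step of a 1.1-fold higher number from compound 1 to compound 3 (0.04 log units; within the scatter) holds the amine fixed and shows that 3-fluorophenyl and 2-(trifluoromethoxy)phenyl on the aromatic nitrogen cannot be told apart either. Going by these compounds, how a morpholine ring or a longer chain would read at this position remains open. No measurement given here bears on why these numbers lie so close.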